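The source may report more compounds than this note shows. Statements on the series, on what has been measured and on what is new or still open speak of the compounds shown alone.

In a functional assay on HCT-116 cells (Homo sapiens) for antiproliferative activity, read by MTT assay, with a stated time of 72 h (on this read-out lower numbers stand for stronger inhibition and higher numbers for weaker inhibition), compound 1 (`O=C(CCc1cccc2c1B(O)OC2)Nc1nccs1`) gives > 100000 nM, which is a limit of the assay and not a number. Among the compounds with values here, compound 2 (`O=C(CCc1cccc2c1B(O)OC2)Nc1cccc(I)c1`) gives 2300 nM, the only actual number so far. Compound 3 (`O=C(CCc1cccc2c1B(O)OC2)Nc1cccc(-c2ccc(Cl)cc2)c1`) keeps the structure of compound 2 except for one group, with 4-chlorophenyl in place of iodo on an aromatic carbon, meta to a large group: 4-chlorophenyl in place of iodo on an aromatic carbon. Within the data shown here, one measured step bears on this change, an at least 43-fold lower number from compound 1 to compound 2 (1.63 log units; beyond the scatter), where 3-iodophenyl replaced 1,3-thiazol-2-yl on an amide-type nitrogen. That large step exchanged the entire group on the nitrogen, whereas the new change leaves the ring bearing the iodo in place. A smaller move toward a lower number is therefore expected in this assay. The expected change is a 2.6-fold lower number from compound 2 to compound 3 (0.41 log units; beyond the scatter). For compound 3 the estimated value is 900 nM, with an expected range of 200 nM to 5000 nM.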

Compound 3, half-maximal inhibitory concentration: 380 nM
For compound 3 the middle estimate is 2.4-fold (0.37 log units) above the measured one; low and high end bracket the measured number.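

Replacing iodo with 4-chlorophenyl on an aromatic carbon, meta to a large group, gives a 6.1-fold lower number from compound 2 to compound 3 (0.78 log units; beyond the scatter). In this assay, this position therefore accepts a whole additional six-membered aromatic ring, and the number still falls. This is also the first step in the series with an actual number at both ends, so its full size can be read, whereas the earlier step can only be bounded, as compound 1 stands at a limit of the assay and not at a number: the limit of > 100000 nM in this assay, at which 1 of the 3 values shown sits.

Going by these compounds, whether the lower number belongs to the added ring itself or to its chlorine remains open, and a plain phenyl or a 4-methoxyphenyl at this position would bear on that. On these data alone, how a ring carrying an amine or a carboxylic acid would read here is equally open.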